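The compounds below may be only part of what the source reports. "The series", "measured", "known", "first", "only" and "open" are said of these compounds alone.

In a physicochemical assay for solubility, in phosphate buffer, measured as kinetic solubility (on this read-out lower numbers stand for lower solubility and higher numbers for higher solubility), compound 1 `CC(C)C(c1ccc(-c2ccc3cccc(F)c3c2)[nH]c1=O)C1SC(=O)NC1=O` gives 20100 nM and compound 2 `CC(C)C(CC1NC(=O)NC1=O)c1ccc(-c2ccc3cccc(F)c3c2)[nH]c1=O` gives 12300 nM. These two numbers lie within the usual scatter of each other, so they cannot be ranked. Compound 3 `CC(C)C(/C=C1/C(=O)NC(=O)N1C)c1ccc(-c2ccc3cccc(F)c3c2)[nH]c1=O` has not yet been measured. It differs from compound 2 at one place, on a saturated chain carbon bound to an aromatic carbon and a saturated chain carbon: a group of 9 heavy atoms (5 carbon, 2 nitrogen, 2 oxygen; one five-membered non-aromatic ring with 2 hetero atoms) in place of a group of 8 heavy atoms (4 carbon, 2 nitrogen, 2 oxygen; one five-membered non-aromatic ring with 2 hetero atoms), on a saturated chain carbon bound to an aromatic carbon and a saturated chain carbon. For the measured compounds named here, only one measured step bears on this, a swap of groups at that same place, and it is a 1.6-fold lower number from compound 1 to compound 2 (0.21 log units; within the scatter). A single step is thin evidence, but it gives no reason to expect a shift beyond the scatter in either direction in this assay. The expected change is a 1.1-fold lower number from compound 2 to compound 3 (0.05 log units; within the scatter). Compound 3 is expected at 11000 nM, with an estimated range of 4000 nM to 28000 nM.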

Compound 3, solubility: 34800 nM
Compound 3: the middle estimate sits 3.2-fold (0.50 log units) below what was measured; measured number outside the range, above it.
By their numbers in this assay, from the lowest: compounds 2, 1 and 3 (each within the scatter of the next, the first and the last beyond it).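

In this assay, the group on a saturated chain carbon bound to an aromatic carbon and a saturated chain carbon can move the number beyond the scatter: the entering group, with 3 double bonds outside aromatic rings rather than 2 and 1 hydrogen-bond donor rather than 2, gives a 2.8-fold higher number from compound 2 to compound 3 (0.45 log units; beyond the scatter) in place of (2,5-dioxoimidazolidin-4-yl)methyl. For the compounds shown here, the one earlier step at this place stayed within the scatter, so this is the first sign that the place is not indifferent to the swap. Set against the 2,4-dioxo-1,3-thiazolidin-5-yl group, the same entering group gives a 1.7-fold higher number from compound 1 to compound 3 (0.24 log units; within the scatter) and so cannot be ranked against it. From the compounds shown here alone, whether an amine or a carboxylic acid at this place would shift the number further remains open. Nothing shown tells which difference between the groups produces the step.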